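Benzyl in Place of 2-Methoxyphenyl on the Ring Amine

A few compounds are considered here, and "the series" means these few. Any claim that something is new, unique, unknown or untested is made for them only; others in the source may bear on it.

Three compounds share one core, differing only in what hangs from the ring nitrogen of that core. Compound 1 `O=C(/C=C/c1ccccc1)c1ccc2[nH]c(=O)oc2c1` carries nothing there, and in a functional assay on K562 cells (Homo sapiens) for cytotoxicity, read by MTT assay, with a stated time of 72 h (a higher number here means a weaker inhibitor, a lower number a stronger inhibitor), compound 1 is recorded as "not determined" (no result reported), so it has no result. Compound 2 `O=C(/C=C/c1ccccc1)c1ccc2c(c1)oc(=O)n2CN1CCCCC1` gives 38300 nM in this assay. Compound 3 `COc1ccccc1N1CCN(Cn2c(=O)oc3cc(C(=O)/C=C/c4ccccc4)ccc32)CC1` gives 30100 nM in this assay. Of the two numbers on record, compound 3 shows the lower one, but the gap to compound 2 lies within the scatter, so the two cannot be told apart; compound 1 contributes no number.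

Compound 4 `O=C(/C=C/c1ccccc1)c1ccc2c(c1)oc(=O)n2CN1CCN(Cc2ccccc2)CC1` has not yet been tested in this assay. It differs from compound 3 by benzyl in place of 2-methoxyphenyl on an amine nitrogen in a ring. For the measured compounds named here, no pair of measured compounds traces a change of this kind, so nothing measured speaks to its size. With both known numbers sitting close together at weak potency, the expected step from the value of compound 3 to that of compound 4 is a 1.1-fold lower number from compound 3 to compound 4 (0.03 log units; within the scatter), and it is expected to stay within the scatter in either direction. On that basis compound 4 is estimated at 28000 nM in this assay, within a range from 9000 nM to 90000 nM.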

Compound 4, half-maximal inhibitory concentration: 29500 nM
For compound 4 the middle estimate is 1.1-fold (0.02 log units) below the measured one, within the range that was stated.
By their numbers in this assay, from the lowest: compounds 4, 3 and 2 (each within the scatter of the next).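

In this assay, for the compounds shown here, the change from 2-methoxyphenyl to benzyl on the amine nitrogen in a ring comes to a 1.0-fold lower number from compound 3 to compound 4 (0.01 log units; within the scatter), and this is the first step measured at this position. The change removes one heavy atom and the only hydrogen-bond acceptor of the leaving group while keeping one six-membered aromatic ring of carbon only, yet compound 3 and compound 4 cannot be told apart here, so this exchange on the ring amine leaves no trace that can be read in this cytotoxicity measure. Nothing available on this pair accounts for the result.

Going by these compounds alone, the single step says nothing about how other groups on this nitrogen would behave: a carboxylic acid or a primary amine on the aromatic ring, or a longer chain in place of benzyl, might or might not give a number beyond the scatter. Whether any substituent at this nitrogen can move the number far from where compound 3 and compound 4 stand therefore remains an open question.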